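The source may hold more compounds than are shown below. What is called first, only, known or untested is meant among the compounds shown, and "the series" means these compounds.

Compound 1, `O=C(Nc1ccc(Oc2ccnc3[nH]ccc23)cc1)c1cn(-c2ccccc2)c2ccccc2c1=O`, gives 1030 nM in a functional assay on A549 cells (Homo sapiens) for inhibition, read by MTT assay, with a stated time of 72 h; on this read-out lower numbers stand for stronger inhibition and higher numbers for weaker inhibition.
Compound 2, `O=C(Nc1ccc(Oc2ccnc3[nH]ccc23)cc1)c1cn(-c2ccc(F)cc2)c2ccccc2c1=O`, gives 390 nM in this assay.

Going by the values given here, compound 2 holds the lowest of the two numbers, its only neighbour being compound 1 across the step of a 2.6-fold lower number from compound 1 to compound 2 (0.42 log units; beyond the scatter). Compound 3, `O=C(Nc1ccc(Oc2ccnc3[nH]ccc23)cc1)c1cn(-c2ccc(Cl)cc2)c2ccccc2c1=O`, differs from compound 2 by chloro in place of fluoro on an aromatic carbon. Among the compounds with values here, the single measured step, a 2.6-fold lower number from compound 1 to compound 2 (0.42 log units; beyond the scatter), concerns fluoro entering in place of hydrogen, not chloro replacing fluoro, so it bears on the new change only loosely. The expectation for this assay is therefore a step no larger than a 1.2-fold lower number from compound 2 to compound 3 (0.07 log units; within the scatter), its direction uncertain. Compound 3 is expected to give about 330 nM, within 150 nM to 800 nM.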

Compound 3, half-maximal inhibitory concentration: 650 nM
Compound 3: the middle estimate sits 2.0-fold (0.29 log units) below what was measured, within the range that was stated.
By their numbers in this assay, from the lowest: compounds 2, 3 and 1 (each within the scatter of the next, the first and the last beyond it).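

The step of a 1.7-fold higher number from compound 2 to compound 3 (0.22 log units; within the scatter) in this assay does not separate chloro from fluoro at this position, para to a large group. The step of a 1.6-fold lower number from compound 1 to compound 3 (0.20 log units; within the scatter) does not separate chloro from hydrogen there either, so compound 3 lies within the scatter of both neighbours, even though compound 1 and compound 2 lie beyond the scatter of each other. Nothing measured here accounts for this reading. The compounds shown leave open what a methoxy group, an amine or a carboxylic acid would give at this position.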